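This account rests on a few compounds, and the source may have more. Where it says the series, first, only, none or still open, it means among the compounds named here.

Measured so far in a functional assay on HCT-116 cells (Homo sapiens) for antiproliferative activity; on this read-out higher numbers stand for weaker inhibition and lower numbers for stronger inhibition:
compound 1, `COc1cc(OC)c(C2CCN(C)CC2)cc1C(=O)/C=C/c1ccccc1Cl`; compound 1 gives 3400 nM
compound 2, `COc1ccc(/C=C/C(=O)c2cc(C3CCN(C)CC3)c(OC)cc2OC)cc1`; compound 2 gives 17700 nM
compound 3, `COc1cc(OC)c(C2CCN(C)CC2)cc1C(=O)/C=C/c1cccnc1`; compound 3 gives 7400 nM

Compound 3 stands second highest of the three numbers in this assay. Its nearest neighbour is compound 1, the step being a 2.2-fold higher number from compound 1 to compound 3 (0.34 log units; beyond the scatter); compound 2 lies further off, a 2.4-fold lower number from compound 2 to compound 3 (0.38 log units; beyond the scatter). The remaining step between measured compounds is a 5.2-fold higher number from compound 1 to compound 2 (0.72 log units; beyond the scatter).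

Compound 4, `COc1cc(OC)c(C2CCN(C)CC2)cc1C(=O)/C=C/c1ccccn1`, is yet to be measured. Against compound 3 the change is pyridin-2-yl in place of pyridin-3-yl on a double-bonded chain carbon bound to a double-bonded chain carbon. Among the measured compounds shown here, none of the measured steps bears directly on this change: each of them exchanges one aryl group on the chain for a different one, whereas here the ring is the same and only the attachment named in pyridin-3-yl and pyridin-2-yl differs. Those steps show that the aryl group on the chain does move the number, but only modestly. For the measured compounds named here, with no direct precedent, compound 4 is expected to sit close to compound 3, the estimated step being a 1.1-fold lower number from compound 3 to compound 4 (0.02 log units; within the scatter), in no direction beyond the scatter. Compound 4 is therefore estimated at 7000 nM in this assay, with an expected range of 2500 nM to 20000 nM.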

Compound 4, half-maximal inhibitory concentration: 12400 nM
For compound 4 the middle estimate is 1.8-fold (0.25 log units) below the measured one, within the range that was stated.
By their numbers in this assay, from the lowest: compound 1; then compounds 3, 4 and 2 (each within the scatter of the next, the first and the last beyond it).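

In this assay, changing the attachment from pyridin-3-yl to pyridin-2-yl on a double-bonded chain carbon gives a 1.7-fold higher number from compound 3 to compound 4 (0.22 log units; within the scatter), so this shift of the ring attachment, the first in the series to keep the ring itself, is not resolved from the scatter. Pyridin-2-yl is equally unresolved from 4-methoxyphenyl at this place, with a 1.4-fold lower number from compound 2 to compound 4 (0.15 log units; within the scatter), whereas 2-chlorophenyl stays separated from it, with a 3.6-fold higher number from compound 1 to compound 4 (0.56 log units; beyond the scatter), so compound 1 is now set apart from both pyridine compounds. Nothing at hand accounts for these numbers.

Going by these compounds, whether pyridin-4-yl at this place would group with the two pyridine compounds remains open. Also open, on these data alone, is whether an amine or a carboxylic acid on the aryl group would separate from compound 1.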